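Trifluoromethyl on the Aryl Ring of a Dienone

A few compounds are considered here, and "the series" means these few. Any claim that something is new, unique, unknown or untested is made for them only; others in the source may bear on it.

Measured compounds:
- compound 1 `CC1=C(/C=C/C(=O)/C=C/c2ccccc2)C(C)(C)CCC1O`: in a functional assay on CWR22R cells (Homo sapiens) for cytotoxicity, read by MTT assay, with a stated time of 72 h (on this read-out lower numbers stand for stronger inhibition and higher numbers for weaker inhibition), compound 1 gives 8000 nM
- compound 2 `CC1=C(/C=C/C(=O)/C=C/c2ccccc2C(F)(F)F)C(C)(C)CCC1O`: in this assay compound 2 gives 2300 nM

Going by the values given here, compound 1 carries no substituent on its phenyl ring and stands at the higher of the two numbers measured so far. Its nearest neighbour is compound 2, reached by a 3.5-fold lower number from compound 1 to compound 2 (0.54 log units; beyond the scatter), a shift that lies outside the ordinary scatter of this kind of measurement.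

Compound 3 `CC1=C(/C=C/C(=O)/C=C/c2ccc(C(F)(F)F)cc2)C(C)(C)CCC1O` is built from compound 1 by one change: trifluoromethyl in place of hydrogen on an aromatic carbon. Among the compounds with values here, the only thing that sets compound 3 apart from compound 2 is where on the ring the trifluoromethyl sits. Within the data shown here, the single measured step that bears on this change is the one from compound 1 to compound 2, which was modest in size and pointed toward a lower number. A step of similar size and direction is therefore expected here, namely a 2.7-fold lower number from compound 1 to compound 3 (0.43 log units; beyond the scatter), with the caution that one example is a thin basis. Compound 3 is estimated at 3000 nM, within a range from 1200 nM to 8000 nM.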

Compound 3, half-maximal inhibitory concentration: 3200 nM
Beside the measured number, compound 3's estimate is 1.1-fold (0.03 log units) below it; the measured number falls inside the stated range.
By their numbers in this assay, from the lowest: compounds 2 and 3 (each within the scatter of the next); then compound 1.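

Placed on an aromatic carbon para to a large group, trifluoromethyl again lowers the number in this assay, with a 2.5-fold lower number from compound 1 to compound 3 (0.40 log units; beyond the scatter), so the drop seen with compound 2 is not confined to a single spot on the ring. Compounds 2 and 3 lie within the usual scatter of each other, which means these results give no order between the two places where the group sits, and the ring position makes no readable difference here. No measurement is available that would explain this result.

Going by these compounds, the ring in these compounds carries only hydrogen or trifluoromethyl, so it stays open whether chlorine, an amine or a carboxylic acid on the same aromatic carbon would move the number in the same direction, or at all. Also open, on these data alone, is whether two trifluoromethyl groups on one ring would lower the number further, and whether the same step would appear in a cell line other than the one used here.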